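Swapping Isopropyl for Iodo: Expecting Another Limit

A few compounds are considered here, and "the series" means these few. Any claim that something is new, unique, unknown or untested is made for them only; others in the source may bear on it.

Three measured compounds share one core and differ only in the group carried on a six-membered aromatic ring of carbon only. Compound 1 `CCCCOc1ccc(C(=O)N/N=C/c2ccc3c(c2)no[n+]3[O-])cc1` carries butoxy, compound 2 `O=C(N/N=C/c1ccc2c(c1)no[n+]2[O-])c1ccc(Br)cc1` carries bromo, and compound 3 `CC(C)c1ccc(C(=O)N/N=C/c2ccc3c(c2)no[n+]3[O-])cc1` carries isopropyl. In an ADME assay on cells (Fibroblast, Homo sapiens) for inhibition, read by MTT assay, with a stated time of 24 h (a higher number here means a weaker inhibitor, a lower number a stronger inhibitor), compound 1 gives > 200000 nM, which is a limit of the assay rather than a number. In this assay compound 2 also reaches only the limit, at > 200000 nM. Compound 3 stands at the same limit, giving > 200000 nM in this assay. Among the measured compounds shown here, because of the limit of > 200000 nM in this assay, at which 3 of the 3 values shown sit, no step between them can be read: the step that the two limits leave unreadable from compound 1 to compound 2, the step that the two limits leave unreadable from compound 1 to compound 3 and the step that the two limits leave unreadable from compound 2 to compound 3 all have a size that is hidden.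

Compound 4 `O=C(N/N=C/c1ccc2c(c1)no[n+]2[O-])c1ccc(I)cc1` has not been measured. It differs from compound 3 by iodo in place of isopropyl on an aromatic carbon. The step that bears most closely on this change is the one from bromo to isopropyl, and its size is unreadable, as is every other step shown. With all three measured values sitting at the limit, the expectation for the step in this assay is a step that the limit leaves unreadable from compound 3 to compound 4, meaning no readable change. Compound 4 is therefore estimated at 250000 nM, within a range from 100000 nM to 1000000 nM, most likely reported again as a limit.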

Compound 4, half-maximal inhibitory concentration: > 200000 nM
Compound 4: a limit, no number (the forecaster's own chance of this, stated with the estimate: 85%); the middle value is on the limit's open side.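

No step from compound 4 to compound 1, compound 2 or compound 3 can be read, because all of them stop at one shared limit: the limit of > 200000 nM in this assay, at which 4 of the 4 values shown sit.

The compounds shown leave open whether iodo, bromo, isopropyl and butoxy differ at all in their effect in this assay, since none of the four gives an actual number there.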